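A few compounds are considered here, and "the series" means these few. Any claim that something is new, unique, unknown or untested is made for them only; others in the source may bear on it.

In a physicochemical assay for lipophilicity, at pH 7.4 (a lower number here means a more polar compound, a higher number a more lipophilic compound), compound 1 `CCS(=O)(=O)c1ccc(CN(CC(C)C)S(=O)(=O)c2ccc3c(c2)C(O)CC(C2CCOCC2)O3)nc1` gives 1.42 and compound 3 `CC(C)CN(c1ccccc1F)S(=O)(=O)c1ccc2c(c1)C(O)CC(C1CCOCC1)O2` gives 3.39 while compound 2 `CCc1ccc(N(CC(C)C)S(=O)(=O)c2ccc3c(c2)C(O)CC(C2CCOCC2)O3)cc1` stands highest of the three at 4.12 on these numbers. Compound 4 `CCc1ccc(N(CC(C)C)S(=O)(=O)c2ccc3c(c2)C(C)CC(C2CCOCC2)O3)cc1` carries methyl in place of hydroxy on a saturated ring carbon of compound 2 (methyl in place of hydroxy on a saturated ring carbon). The measured steps all sit on a sulfonamide nitrogen, two large (a number 2.70 log units higher from compound 1 to compound 2 (beyond the scatter) and a number 1.97 log units higher from compound 1 to compound 3 (beyond the scatter)) and one modest (a number 0.73 log units lower from compound 2 to compound 3 (beyond the scatter)). None changes this ring carbon, so they give only a sense of scale and the size expected here rests on the structural change alone. A clear rise beyond the scatter is expected (a number 0.98 log units higher from compound 2 to compound 4 (beyond the scatter)). The estimate for compound 4 is an expected 5.1 (range 4.6 to 5.6).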

Compound 4, distribution coefficient: 5.71
For compound 4 the middle estimate is 0.61 log units below the measured one, outside the stated range (above it).
By their numbers in this assay, from the lowest: compound 1; then compound 3; then compound 2; then compound 4.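

In this assay, methyl in place of hydroxy on the saturated ring carbon gives a number 1.59 log units higher from compound 2 to compound 4 (beyond the scatter), the only step shown at this position, since the earlier steps all sit on the sulfonamide nitrogen. This single heavy-atom exchange, which removes a hydrogen-bond donor and a hydrogen-bond acceptor, is a large step, so the ring carbon also moves this read-out strongly. Nothing measured here bears on the reason for its size.

As far as these compounds go, only hydroxy and methyl appear at this ring carbon, so a methoxy group, an amine or a fluorine there remains open. From the compounds shown here alone, whether the step holds with 2-fluorophenyl or (5-(ethylsulfonyl)pyridin-2-yl)methyl on the sulfonamide nitrogen also remains open.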